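The source may report more compounds than this note shows. Statements on the series, on what has been measured and on what is new or still open speak of the compounds shown alone.

Measured so far:
compound 1 `CS(=O)(=O)c1cccc(-c2ccc3ncc(-c4ccc(S(=O)(=O)CCCN)cc4)n3n2)c1` — > 200000 nM
compound 2 `CS(=O)(=O)c1cncc(-c2ccc3ncc(-c4ccc(S(C)(=O)=O)nc4)n3n2)c1` — 52000 nM
compound 3 `CS(=O)(=O)c1ccc(-c2cnc3ccc(-c4cccc(S(=O)(=O)CCO)c4)nn23)cc1` — 190000 nM

In a physicochemical assay for solubility, at pH 2 (a lower number here means a less soluble compound, a higher number a more soluble compound), compound 1 gives > 200000 nM, which is a limit of the assay and not a number; compound 1 therefore stands at the limit of > 200000 nM in this assay, at which 1 of the 3 values shown sits. Compound 2 gives 52000 nM and compound 3 gives 190000 nM in this assay. Compound 4 `CS(=O)(=O)c1cccc(-c2ccc3ncc(-c4ccc(S(=O)(=O)N5CCNCC5)cc4)n3n2)c1` differs from compound 1 in one place: piperazin-1-yl in place of 3-aminopropyl on a sulfonyl sulfur. For the measured compounds named here, no pair of measured compounds differing in one place is available, so no measured step guides the expectation. Compound 4 is expected to stay near the same level as compound 1, with an at least 1.3-fold lower number from compound 1 to compound 4 (0.12 log units; that floor lies within the scatter) amounting to no step beyond the scatter. Compound 4 is thus estimated at 150000 nM, in the range 40000 nM to 300000 nM.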

Compound 4, solubility: 166000 nM
Estimate against measurement, compound 4: 1.1-fold (0.04 log units) below, within the range that was stated.
By their numbers in this assay, from the lowest: compound 2; then compounds 4 and 3 (each within the scatter of the next). At a limit, above all of these: compound 1.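

In this assay compound 1 stands at a limit of the assay, > 200000 nM, which is not a number. With piperazin-1-yl in place of 3-aminopropyl on a sulfonyl sulfur, this position now has a measured value, and the step reads an at least 1.2-fold lower number from compound 1 to compound 4 (0.08 log units; that floor lies within the scatter). Only that floor can be read, so the ring-bearing group is not shown to differ from the open chain, and the true size of the step stays unknown: the limit of > 200000 nM in this assay, at which 1 of the 4 values shown sits.

On these data alone, whether a carboxylic acid or a morpholine on the same sulfonyl sulfur would give a similar number remains open. So does whether a longer amine chain would stay at the limit.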